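Swapping hydrogen for phenyl on the shared core

The source may report more compounds than this note shows. Statements on the series, on what has been measured and on what is new or still open speak of the compounds shown alone.

Compound 1 `Cc1csc2nc(Cn3cnc4ccccc43)cc(=O)n12`: 8 mL.min-1.g-1
Compound 2 `O=c1cc(Cn2cnc3ccccc32)nc2sccn12`: 8 mL.min-1.g-1
Compound 3 `Cc1cn2c(=O)cc(Cn3cnc4ccccc43)nc2s1`: 8 mL.min-1.g-1

In an ADME assay on microsomes from liver (Homo sapiens) for metabolic stability (on this read-out higher numbers stand for fast clearance and lower numbers for slow clearance), compound 2 stands level with compound 1 and compound 3 at the digits shown. Compound 4 `O=c1cc(Cn2cnc3ccccc32)nc2scc(-c3ccccc3)n12` differs from compound 2 as follows: phenyl in place of hydrogen on an aromatic carbon. The closest measured step is no change at the digits printed from compound 1 to compound 2 (within the scatter), in which methyl leaves the carbon that carries phenyl in compound 4. Methyl enters at another aromatic carbon in no change at the digits printed from compound 2 to compound 3 (within the scatter). Neither step involves phenyl, a much larger group than methyl, so they guide the estimate only loosely. A modest upward move is expected, with an estimated size of a 2.3-fold higher number from compound 2 to compound 4 (0.35 log units; beyond the scatter). Compound 4 is expected to give 18 mL.min-1.g-1, with an estimated range from 8 mL.min-1.g-1 to 40 mL.min-1.g-1.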

Compound 4, intrinsic clearance in microsomes: 8 mL.min-1.g-1
Compound 4: the middle estimate sits 2.3-fold (0.35 log units) above what was measured; measured number inside the range.
By their numbers in this assay, from the lowest: compounds 1, 2, 3 and 4 (each within the scatter of the next).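

In this assay, phenyl in place of hydrogen on this aromatic carbon next to the ring nitrogen gives no change at the digits printed from compound 2 to compound 4 (within the scatter), and phenyl in place of methyl gives no change at the digits printed from compound 1 to compound 4 (within the scatter). Until now this carbon had carried only hydrogen or methyl, so the read-out is now seen to stay level with a whole six-membered aromatic ring there as well. Nothing measured here gives a reason for this result. Still open, going by these compounds, is whether an amine or a carboxylic acid on this carbon would leave the read-out equally level. For the compounds shown here, also open is whether phenyl would do the same on the other aromatic carbon, the one bearing methyl in compound 3.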